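The source may hold more compounds than are shown below. What is called first, only, known or untested is meant among the compounds shown, and "the series" means these compounds.

In an ADME assay on Vero cells (Chlorocebus sabaeus) for cytotoxicity, read by resazurin assay, with a stated time of 72 h (on this read-out lower numbers stand for stronger inhibition and higher numbers for weaker inhibition), compound 1 `Cc1ccc(C(=O)CCN2CCN(c3ccc([N+](=O)[O-])cc3)CC2)cc1` gives 235000 nM, compound 2 `COc1ccc(C(=O)CCN2CCN(c3ccc([N+](=O)[O-])cc3)CC2)cc1` gives 587000 nM, and compound 3 `O=C(CCN1CCN(c2ccc(Cl)cc2)CC1)c1ccc(OC(F)(F)F)cc1` gives 95600 nM, the lowest of the three numbers. Compound 4 `O=C(CCN1CCN(c2ccc([N+](=O)[O-])cc2)CC1)c1ccc(OC(F)(F)F)cc1` differs from compound 3 by nitro in place of chloro on an aromatic carbon, para to a large group: nitro in place of chloro on an aromatic carbon. Among the compounds with values here, no measured step makes this exact change. Within the data shown here, the one measured step, a 2.5-fold higher number from compound 1 to compound 2 (0.40 log units; beyond the scatter), concerns methoxy in place of methyl at a different place, so it shows only how far a single change has moved the number here. Compound 1 and compound 2 both carry the 4-nitrophenyl group, and both values lie above that of compound 3. The expected step is therefore modest and upward, a 2.0-fold higher number from compound 3 to compound 4 (0.30 log units; within the scatter). For compound 4 the estimated value is 190000 nM, with an expected range from 85000 nM to 430000 nM.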

Compound 4, half-maximal inhibitory concentration: 93200 nM
Beside the measured number, compound 4's estimate is 2.0-fold (0.31 log units) above it, and the stated range covers the measured number.
By their numbers in this assay, from the lowest: compounds 4 and 3 (each within the scatter of the next); then compound 1; then compound 2.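

In this assay the change from 4-chlorophenyl to 4-nitrophenyl gives a 1.0-fold lower number from compound 3 to compound 4 (0.01 log units; within the scatter) and so leaves compound 3 and compound 4 indistinguishable at this place. With the 4-nitrophenyl group kept, the other end of the molecule matters: there is a 6.3-fold lower number from compound 2 to compound 4 (0.80 log units; beyond the scatter) for trifluoromethyl in place of methyl on the oxygen, and a 2.5-fold lower number from compound 1 to compound 4 (0.40 log units; beyond the scatter) where trifluoromethoxy takes over from methyl. Nothing available explains these results. Still open, as far as these compounds go, is whether an amine or a carboxylic acid at this place would match chloro and nitro, and whether chloro and nitro would still match with methyl or methoxy in place of trifluoromethoxy.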